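From furan-2-yl to 4-aminophenyl on compound 1

The source may hold more compounds than are shown below. What is called first, only, known or untested is meant among the compounds shown, and "the series" means these compounds.

- compound 1 `O=C(NO)c1cc(F)c(Cn2nnc(-c3ccco3)n2)c(F)c1` gives 100%
- compound 2 `Cn1c(Sc2c(F)cc(C(=O)NO)cc2F)nnc1-c1cccnn1` gives 100%
- compound 3 `Cn1c(Sc2c(F)cc(C(=O)NO)cc2F)nnc1-c1cccc(CN2CCCCCC2)c1` gives 91%

These numbers come from an ADME assay on a cell-free system (plasma, Homo sapiens) for metabolic stability, read by LC-MS, with a stated time of 4 h, tested at 100 uM (a higher number here means that more of the compound is left, a lower number that less of the compound is left), and show no clear separation. Compound 1 stands level with compound 2, and compound 3 lies within the usual scatter of both. Compound 4 `Nc1ccc(-c2nnn(Cc3c(F)cc(C(=O)NO)cc3F)n2)cc1` keeps the core of compound 1 and carries 4-aminophenyl in place of furan-2-yl on an aromatic carbon. Among the measured compounds shown here, no two measured compounds differ in one place only, so this swap has no direct precedent. Compound 3, with a very different structure, still gives 91% and so no step beyond the scatter is expected in this assay here. The expected change is a number 5 percentage points lower from compound 1 to compound 4 (within the scatter) and would stay inside the scatter. For compound 4 the estimated value is 95% with a likely range (82% to 100%).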

Compound 4, percent of the compound remaining: 88%
The estimate for compound 4 lay 7 percentage points above the measured number; the range from low to high includes it.
By their numbers in this assay, from the lowest: compounds 4, 3, 1 and 2 (each within the scatter of the next, the first and the last beyond it).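

In this assay, among the compounds shown here, 4-aminophenyl in place of furan-2-yl gives a number 12 percentage points lower from compound 1 to compound 4 (beyond the scatter) and thus the only step here that can be read between compounds differing in one place. It shows that the group on this aromatic carbon can change how much compound is left, although the step is modest and rests on a single pair. Nothing available explains this step.

The compounds shown leave open whether the step follows the six-membered ring or its amine. Plain phenyl, or a 4-carboxyphenyl group, on the same carbon would help separate the two.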